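Working notes: methoxycarbonyl to trifluoromethyl in compound 3

The compounds below may be only part of what the source reports. "The series", "measured", "known", "first", "only" and "open" are said of these compounds alone.

Among the compounds with values here, in a physicochemical assay for solubility, at pH 7.4 (on this read-out higher numbers stand for higher solubility and lower numbers for lower solubility), compound 1 (`CC(=O)c1ccc(NC(=O)Nc2cc(C)nc3ccccc23)cc1`) gives 3800 nM and compound 2 (`COC(=O)c1ccc(NC(=O)Nc2cc(C)nc3ccccc23)cc1`) gives 1200 nM as the lower of the two numbers so far. Compound 3 (`Cc1cc(NC(=O)Nc2ccc(C(F)(F)F)cc2)c2ccccc2n1`) has trifluoromethyl in place of methoxycarbonyl on an aromatic carbon, para to a large group (trifluoromethyl in place of methoxycarbonyl on an aromatic carbon). Within the data shown here, no measured step covers this exchange directly. Among the measured compounds shown here, the one step that bears on it is a 3.2-fold lower number from compound 1 to compound 2 (0.50 log units; beyond the scatter) and it is modest but beyond the scatter. That step came with methoxy in place of methyl on a carbonyl carbon, within the group that now leaves altogether. A single step is thin support for direction or size, and the exchange here is larger than an edit within the group. Even so, a step of similar modest size towards a lower number is expected in this assay rather than none. The estimate amounts to an expected 3.0-fold lower number from compound 2 to compound 3 (0.48 log units; beyond the scatter) with wide margins. Compound 3 is estimated at 400 nM (expected range 120 nM to 1200 nM).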

Compound 3, solubility: 100 nM
Compound 3: middle estimate off by 4.0-fold (0.60 log units), on the high side, and the stated range ends above it.
By their numbers in this assay, from the lowest: compound 3; then compound 2; then compound 1.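

In this assay, exchanging the whole group at this position moves the number much further than the edit within the carbonyl group did, with a 12-fold lower number from compound 2 to compound 3 (1.08 log units; beyond the scatter) set against the modest 3.2-fold lower number from compound 1 to compound 2 (0.50 log units; beyond the scatter) for that edit. The same holds against the acetyl compound, with a 38-fold lower number from compound 1 to compound 3 (1.58 log units; beyond the scatter) on the same aromatic carbon, para to a large group, so among these three compounds the two that carry a carbonyl group at this position both stand above the one with trifluoromethyl, and none goes against that order. The position is therefore far from indifferent to what sits on it in this read-out, but no measurement at hand accounts for the size of the drop.

Three compounds cannot say whether the number follows the loss of the carbonyl group or something particular to trifluoromethyl, and a nitrile or a primary amide on the same aromatic carbon would help to separate the two. Also open, going by these compounds, is how an amine or a carboxylic acid at this position would read on the shared core, and whether steps of this size carry over to changes elsewhere on it.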